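This account rests on a few compounds, and the source may have more. Where it says the series, first, only, none or still open, it means among the compounds named here.

In an ADME assay on microsomes from liver (Homo sapiens) for metabolic stability, read by LC-MS, with a stated time of 10 min (on this read-out lower numbers stand for a less stable compound and higher numbers for a more stable compound), three compounds sharing one core have been measured. Compound 3 `C[C@@H]1CN(c2cccc3c2C[C@H](CN(C)[C@H]2CCCc4cccnc42)NC3)C[C@H](C)N1C` stands lowest at 24.6%, while compound 1 `CN(C[C@H]1Cc2c(cccc2N2CCN3CCC[C@H]3C2)CN1)[C@H]1CCCc2cccnc21` gives 36.6% and compound 2 `CN1CCN(c2cccc3c2C[C@H](CN(C)[C@H]2CCCc4cccnc42)NC3)CC1` gives 75.8%. Compound 4 `CN(C[C@H]1Cc2c(cccc2N2C[C@@H]3C[C@H]2CN3)CN1)[C@H]1CCCc2cccnc21` has not yet been measured. It differs from compound 3 in one place, on an aromatic carbon of a six-membered aromatic ring of carbon only: a group of 7 heavy atoms (5 carbon, 2 nitrogen; 2 five-membered non-aromatic rings with 1 hetero atom each) in place of a group of 9 heavy atoms (7 carbon, 2 nitrogen; one six-membered non-aromatic ring with 2 hetero atoms), on an aromatic carbon.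

All three measured steps change the group at this same place: a number 39.2 percentage points higher from compound 1 to compound 2 (beyond the scatter), a number 12 percentage points lower from compound 1 to compound 3 (beyond the scatter) and a number 51.2 percentage points lower from compound 2 to compound 3 (beyond the scatter). Two of these are large and one is modest, so the readings respond strongly to changes here. Among the measured compounds shown here, no measured compound carries the entering group, which means that no step speaks to it directly. The nearest guide is compound 2 at 75.8%, whose group matches the entering one in its count of heavy atoms but not in its rings. On that evidence, a large rise is expected in this assay, with wide uncertainty and probably not the full height of compound 2. The estimated change is a number 33.4 percentage points higher from compound 3 to compound 4 (beyond the scatter). For compound 4 the expected value is 58%, with an estimated range from 33% to 83%.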

Compound 4, percent of the compound remaining: 100%
Beside the measured number, compound 4's estimate is 42 percentage points below it; measured number outside the range, above it.
By their numbers in this assay, from the lowest: compound 3; then compound 1; then compound 2; then compound 4.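

In this assay, the group with 2 five-membered non-aromatic rings with 1 hetero atom each puts compound 4 at the top of the series, with a number 75.4 percentage points higher from compound 3 to compound 4 (beyond the scatter) and a number 63.4 percentage points higher from compound 1 to compound 4 (beyond the scatter) and also a number 24.2 percentage points higher from compound 2 to compound 4 (beyond the scatter), each beyond the scatter. The last of these steps shows that the count of heavy atoms does not settle the reading at this aromatic carbon: two groups of 7 heavy atoms, both with 5 carbon and 2 nitrogen, still give clearly different numbers, although among these four compounds both groups of 7 heavy atoms stand above both groups of 9, and no compound goes against that order. Nothing at hand accounts for these differences.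

The compounds shown leave open whether the rise follows the two-ring form of the entering group or its 1 hydrogen-bond donor, as these two features change together in this set. A plain piperazin-1-yl, or the entering group with a methyl on its free ring nitrogen, would separate the two.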